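The compounds below may be only part of what the source reports. "The series", "measured", "known", "first", "only" and "open" are said of these compounds alone.

In a functional assay on NCI-H1581 cells (Homo sapiens) for antiproliferative activity, read by CCK-8 assay, with a stated time of 72 h (on this read-out lower numbers stand for stronger inhibition and higher numbers for weaker inhibition), compound 1 `COc1cc(OC)c(Cl)c(-c2ccc3c(NC(=O)c4ccc(N5CCN(C)CC5)cc4)n[nH]c3n2)c1Cl` gives 1.7 nM and compound 2 `COc1cc(OC)c(Cl)c(-c2ccc3c(NC(=O)c4ccc(N5CCCN(C)CC5)cc4)n[nH]c3n2)c1Cl` gives 1.3 nM, two values within the scatter of each other. Compound 3 `COc1cc(OC)c(Cl)c(-c2ccc3c(NC(=O)c4ccc(N5CCN(C6CCC6)CC5)cc4)n[nH]c3n2)c1Cl` keeps the shared core but carries 4-cyclobutylpiperazin-1-yl in place of 4-methyl-1,4-diazepan-1-yl on an aromatic carbon. For the measured compounds named here, the one measured step at this place is a 1.3-fold lower number from compound 1 to compound 2 (0.12 log units; within the scatter), which stayed within the scatter. Going by the values given here, no measured compound carries the cyclobutyl group, but no step beyond the scatter is expected in this assay. For compound 3 the estimated value is 2 nM, with an expected range of 0.8 nM to 6 nM. This estimate means an expected 1.5-fold higher number from compound 2 to compound 3 (0.19 log units; within the scatter).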

Compound 3, half-maximal inhibitory concentration: 2.3 nM
For compound 3 the middle estimate is 1.2-fold (0.06 log units) below the measured one, and the stated range covers the measured number.
By their numbers in this assay, from the lowest: compounds 2, 1 and 3 (each within the scatter of the next).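

In this assay cyclobutyl in place of methyl on the amine nitrogen in the ring gives a 1.4-fold higher number from compound 1 to compound 3 (0.13 log units; within the scatter) while 4-cyclobutylpiperazin-1-yl in place of 4-methyl-1,4-diazepan-1-yl gives a 1.8-fold higher number from compound 2 to compound 3 (0.25 log units; within the scatter) and both steps stay within the scatter. The earlier step changed only the ring, whereas these show that the substituent on that nitrogen can also grow from methyl to cyclobutyl without a step beyond the scatter. Nothing available explains this. Still open, on these data alone, is how a hydroxyethyl or acetyl group on that nitrogen, or a morpholine in place of the piperazine, would read.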